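The source may report more compounds than this note shows. Statements on the series, on what has been measured and on what is new or still open speak of the compounds shown alone.

Measured so far in a functional assay on DU-145 cells (Homo sapiens) for inhibition, read by trypan blue exclusion, with a stated time of 96 h; on this read-out lower numbers stand for stronger inhibition of growth and higher numbers for weaker inhibition of growth:
compound 1, `Cc1ccc(S(=O)(=O)/C(=C/c2ccccc2OCc2ccccc2)C(=O)c2ccc(Br)cc2)cc1`: 1000 nM
compound 2, `O=C(/C(=C\c1ccccc1OCc1ccccc1)S(=O)(=O)Cc1ccc(Cl)cc1)c1ccc(Br)cc1`: 10000 nM
compound 3, `Cc1ccc(S/C(=C/c2ccc(N(C)C)cc2)C(=O)c2ccc(Br)cc2)cc1`: only a limit, > 100000 nM

Compound 2 differs from compound 1 by 4-chlorobenzyl in place of 4-methylphenyl on a sulfonyl sulfur, and this gave a 10-fold higher number from compound 1 to compound 2 (1.00 log units; beyond the scatter). Compound 4, `CN(C)c1ccc(/C=C(/SCc2ccc(Cl)cc2)C(=O)c2ccc(Br)cc2)cc1`, is not yet measured; it differs from compound 3 by 4-chlorobenzyl in place of 4-methylphenyl on a sulfur. This is the same kind of change, but the place differs: in compound 1 the sulfur is a sulfonyl sulfur, in compound 3 a plain sulfur, each with a double-bonded chain carbon as other neighbour. How the core of compound 3 differs from the core of compound 1 is not broken down here. For compound 3 only a limit is known, (the limit of > 100000 nM in this assay, at which 1 of the 3 values shown sits). Since the measured step weakened inhibition, compound 4 is expected no stronger, with a step that the limit leaves unreadable from compound 3 to compound 4. Compound 4 is estimated at 300000 nM, likely between 100000 nM and 2000000 nM, and most probably again reported only as a limit.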

Compound 4, concentration for 50% growth inhibition: 10000 nM
Beside the measured number, compound 4's estimate is 30-fold (1.48 log units) above it, and the stated range ends above it.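

Compound 3 stands only as a limit, > 100000 nM. In this assay, 4-chlorobenzyl in place of 4-methylphenyl gives an at least 10-fold lower number from compound 3 to compound 4 (1.00 log units; beyond the scatter), so the change does not keep its direction from one core to the other: the same change on two cores in this assay, a 10-fold higher number (1.00 log units; beyond the scatter) from compound 1 to compound 2 and an at least 10-fold lower number (1.00 log units; beyond the scatter) from compound 3 to compound 4, at least 100-fold (2.00 log units) apart, beyond the scatter of two such steps

The core of compound 1 and the core of compound 3 are not compared part by part, so these data do not show which part of them goes with the reversal, nor how large the step from compound 3 really is.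

Still open, going by these compounds, is how a 4-chlorophenyl or an unsubstituted benzyl on the sulfur would read on either core. On these data alone, a sulfinyl sulfur in place of the sulfonyl or plain sulfur is equally open.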